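The source may report more compounds than this note shows. Statements on the series, on what has been measured and on what is new or still open speak of the compounds shown alone.

Measured so far:
- compound 1 `O=C1NCc2c1c1c(c3c2c2ccccc2n3CCO)CCc2cc(OC3CCCCC3)ccc2-1`: 4%
- compound 2 `O=C1NCc2c1c1c(c3c2c2ccccc2n3CCO)CCc2cc(OCCO)ccc2-1`: 46%
- compound 3 `O=C1NCc2c1c1c(c3c2c2ccccc2n3CCO)CCc2cc(OCC3CC3)ccc2-1`: 32%

All three share one core and differ only in the group on an oxygen on an aromatic ring. In an assay on isolated protein for inhibition of mitogen-activated protein kinase kinase kinase 11 (Homo sapiens), tested at 1 uM (on this read-out lower numbers stand for less inhibition and higher numbers for more inhibition at the one concentration tested (going by the name of the read-out)), compound 1, which carries a cyclohexyl there, gives 4%. Compound 2, with a 2-hydroxyethyl, gives 46%, and compound 3, with a cyclopropylmethyl, gives 32%. Compound 3 therefore stands second highest of the three: a number 14 percentage points lower from compound 2 to compound 3 (beyond the scatter), while a number 28 percentage points higher from compound 1 to compound 3 (beyond the scatter).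

Compound 4 `O=C1NCc2c1c1c(c3c2c2ccccc2n3CCO)CCc2cc(OCCOCc3ccccc3)ccc2-1` is not yet measured. Relative to compound 3 the change is (benzyloxy)methyl in place of cyclopropyl on a saturated chain carbon bound to an oxygen on an aromatic ring. Going by the values given here, two measured steps bear on this. The move from the bulky cyclohexyl of compound 1 to the smaller cyclopropylmethyl of compound 3 raised inhibition: a number 28 percentage points higher from compound 1 to compound 3 (beyond the scatter). The move from the hydroxymethyl of compound 2 to the cyclopropyl of compound 3 lowered it: a number 14 percentage points lower from compound 2 to compound 3 (beyond the scatter). Among the compounds with values here, the entering (benzyloxy)methyl is much larger than the cyclopropyl it replaces, which points toward a lower number, while its single acceptor recalls compound 2, which points the other way. On balance a modest downward step is expected: a number 12 percentage points lower from compound 3 to compound 4 (beyond the scatter). Compound 4 is estimated at 20%, within a range from 5% to 40%.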

Compound 4, a percentage reported as inhibition, at one concentration (the size of the read-out at that concentration, not a potency): 0%
Compound 4: middle estimate off by 20 percentage points, on the high side; measured number outside the range, below it.
By their numbers in this assay, from the lowest: compounds 4 and 1 (each within the scatter of the next); then compound 3; then compound 2.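

In this assay, the change to compound 4 brings in a (benzyloxy)methyl of 9 heavy atoms in place of a cyclopropyl of 3, and the inhibition seen with the smaller group is lost: a number 32 percentage points lower from compound 3 to compound 4 (beyond the scatter). Putting a benzyl in place of the hydrogen on the oxygen at the end of the 2-hydroxyethyl chain gives a number 46 percentage points lower from compound 2 to compound 4 (beyond the scatter), so the oxygen kept inside the chain is not enough on its own to hold the inhibition of compound 2. The comparison with the cyclohexyl gives a number 4 percentage points lower from compound 1 to compound 4 (within the scatter), so these two quite different groups cannot be told apart here, and among these four compounds the two groups with the most heavy atoms on the oxygen on an aromatic ring are the two with little inhibition, with no compound shown going against this.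

Nothing measured alongside these numbers explains the differences. On these data alone, it remains open whether the benzyl ring or simply the length of the group matters, and a 2-methoxyethyl, or a chain of the same length ending in an amine or a carboxylic acid, would help separate these possibilities.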